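A few compounds are considered here, and "the series" means these few. Any claim that something is new, unique, unknown or untested is made for them only; others in the source may bear on it.

Measured so far: compound 2 `C=CCOC[C@H]1CN(C)CC[C@@H]1c1ccc(Cl)cc1` gives 20 nM in an assay on Cortex with Norepinephrine transporter (Rattus norvegicus) as the target; a higher number here means a weaker inhibitor, a lower number a stronger inhibitor; compound 3 `COC(=O)/C=C/[C@H]1CN(C)CC[C@@H]1c1ccc(Cl)cc1` gives 272 nM; compound 1 `CN1CC[C@H](c2ccc(Cl)cc2)C(C(=O)Oc2ccccc2)C1` gives 2180 nM.

Compound 2 stands lowest of the three numbers, well separated from compound 3 and further still from compound 1. Compound 4 `CN1CC[C@H](c2ccc(Cl)cc2)[C@@H](CCCF)C1` differs from compound 2 in one place: 2-fluoroethyl in place of allyloxy on a saturated chain carbon bound to a saturated ring carbon. Going by the values given here, the only measured step at the same position is a 14-fold higher number from compound 2 to compound 3 (1.13 log units; beyond the scatter), a large loss when a different group replaced the (allyloxy)methyl chain. That step does not involve the 2-fluoroethyl group, so its size is only a rough guide, but it shows that changes here can matter. A moderate weakening is therefore expected, smaller than that step. Compound 4 is estimated at 60 nM, range 15 nM to 250 nM, an expected step of a 3.0-fold higher number from compound 2 to compound 4 (0.48 log units; beyond the scatter).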

Compound 4, inhibition constant: 356 nM
Estimate against measurement, compound 4: 5.9-fold (0.77 log units) below, and the stated range ends below it.
By their numbers in this assay, from the lowest: compound 2; then compounds 3 and 4 (each within the scatter of the next); then compound 1.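

In this assay, putting 3-fluoropropyl in place of (allyloxy)methyl gives an 18-fold higher number from compound 2 to compound 4 (1.25 log units; beyond the scatter), so a second, quite different replacement at this position also gives a much higher number. The 3-fluoropropyl and 2-(methoxycarbonyl)ethenyl groups cannot be told apart here, with a 1.3-fold higher number from compound 3 to compound 4 (0.12 log units; within the scatter). No measurement at hand offers a reason for the loss. Still open, as far as these compounds go, is which part of the (allyloxy)methyl chain matters, its oxygen or its double bond. A plain butyl chain, a methoxymethyl group or a chain ending in an amine would help to separate these.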